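The source may report more compounds than this note shows. Statements on the series, on what has been measured and on what is new or still open speak of the compounds shown alone.

Working notes on the series. Compound 1 `O=C(NC1CCCCC1)C1CCN(c2nc3cc(Cl)ccc3o2)CC1` carries a plain cyclohexyl on the amide nitrogen of the shared core. In a physicochemical assay for solubility, read by nephelometry, in phosphate buffer, at pH 7.4 (a higher number here means a more soluble compound, a lower number a less soluble compound), compound 1 gives only a limit of the assay, < 3000 nM. Compound 2 `Cc1cc2oc(N3CCC(C(=O)N[C@H]4CCC[C@H](CO)C4)CC3)nc2cc1Cl` bears 3-(hydroxymethyl)cyclohexyl on that nitrogen, and in this assay compound 2 gives 65000 nM. Within the data shown here, compound 3 `Cc1cc2oc(N3CCC(C(=O)N[C@H]4CC[C@](C)(O)CC4)CC3)nc2cc1Cl` carries 4-hydroxy-4-methylcyclohexyl in its place; in this assay compound 3 gives 22000 nM, the lowest of the two numbers measured so far, the step of a 3.0-fold lower number from compound 2 to compound 3 (0.47 log units; beyond the scatter) lying beyond the scatter. One of the three values shown sits at a limit (the limit of < 3000 nM in this assay, at which 1 of the 3 values shown sits).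

Compound 4 `Cc1cc2oc(N3CCC(C(=O)N[C@H]4CC[C@@](O)(C(F)(F)F)CC4)CC3)nc2cc1Cl` differs from compound 3 by trifluoromethyl in place of methyl on a saturated ring carbon. Among the measured compounds shown here, no measured step touches this group: the only step available, a 3.0-fold lower number from compound 2 to compound 3 (0.47 log units; beyond the scatter), exchanges the whole substituent on the amide nitrogen and gives no direct guide to a swap of methyl for trifluoromethyl on the saturated ring carbon. With compound 3 already at the lower end of the measured numbers and a limit sitting not far beneath it, a modest step downward in this assay is expected, a 2.2-fold lower number from compound 3 to compound 4 (0.34 log units; beyond the scatter), with a real chance that only a limit is reported. The estimate for compound 4 in this assay is 10000 nM, expected to fall between 3500 nM and 28000 nM.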

Compound 4, solubility: > 100000 nM
Compound 4: a limit, no number; the forecaster's own chance of this, stated with the estimate: 25%; middle value at least 10-fold (1.00 log units) away from the limit.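

Among these compounds, the saturated ring carbon three ring bonds from the ring atom that bears a large group is not a silent position in this assay: trifluoromethyl in place of methyl there gives an at least 4.5-fold higher number from compound 3 to compound 4 (0.65 log units; beyond the scatter), an upward move at a single group, where the earlier compounds offered only an exchange of the whole substituent on the amide nitrogen. Among the compounds shown here, compound 4 reads as a limit and not as a number, so the full size of this step stays unknown, and the series now has a limit at each end of its range, the upper one being: the limit of > 100000 nM in this assay, at which 1 of the 4 values shown sits. By the count of the change, only fluorine is added and no hydrogen-bond donor or acceptor enters or leaves, but this single pair is the only reading of the swap and supports no general rule.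

Open, as far as these compounds go, is whether other groups on this carbon, such as ethyl, a nitrile, an amine or a carboxylic acid, would move the number the same way. Also open, from the compounds shown here alone, is whether trifluoromethyl at this position would give a step of the same direction on the core of compound 1.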